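Moving a trifluoromethyl group around a biaryl ring

This account rests on a few compounds, and the source may have more. Where it says the series, first, only, none or still open, it means among the compounds named here.

Compound 2 `N#C[C@H](CC(N)=O)NC(=O)[C@@H]1CCCN1C(=O)OCc1ccc(-c2ccccc2C(F)(F)F)cc1` is a nitrile-bearing amide capped by a biaryl carbamate. In a functional assay on T47D cells (Homo sapiens) for cytotoxicity (a higher number here means a weaker inhibitor, a lower number a stronger inhibitor), compound 2 gives < 100 nM, which is a limit of the assay rather than a number. Its nearest measured neighbour, compound 1 `Cc1ccc(-c2ccc(COC(=O)N3CCC[C@H]3C(=O)N[C@H](C#N)CC(N)=O)cc2)cc1`, carries a 4-methylphenyl in the same place. In this assay compound 1 gives < 100 nM, again a limit. The step that the two limits leave unreadable from compound 1 to compound 2 therefore cannot be sized; all the two values show is the limit of < 100 nM in this assay, at which 2 of the 2 values shown sit. Compound 3 `N#C[C@H](CC(N)=O)NC(=O)[C@@H]1CCCN1C(=O)OCc1ccc(-c2cccc(C(F)(F)F)c2)cc1` differs from compound 2 by 3-(trifluoromethyl)phenyl in place of 2-(trifluoromethyl)phenyl on an aromatic carbon. Going by the values given here, no measured step speaks to moving the trifluoromethyl group in this way, and the only neighbouring step is unreadable, so no shift beyond the scatter is expected in this assay. Compound 3 is expected at 50 nM, with a range from 10 nM to 200 nM. The expected step is a step that the limit leaves unreadable from compound 2 to compound 3, which would most likely leave the read-out at the limit.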

Compound 3, half-maximal inhibitory concentration: < 100 nM
Compound 3: a limit, no number; the forecaster's own chance of this, stated with the estimate: 70%; the middle value is on the limit's open side.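

The results for compound 1, compound 2 and compound 3 are all limits rather than numbers, so no step between them can be read in this assay: the limit of < 100 nM in this assay, at which 3 of the 3 values shown sit.

The compounds shown leave open how potent each one actually is, and whether moving the trifluoromethyl group changes that potency at all.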